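Exchanging Nitro for Amino on Compound 2

A few compounds are considered here, and "the series" means these few. Any claim that something is new, unique, unknown or untested is made for them only; others in the source may bear on it.

compound 1 `COc1ccc(/C=C2\Cc3c(cc(OC)c(OC)c3OC)C2=O)cc1O`: 172 nM
compound 2 `COc1ccc(/C=C2\Cc3c(cc(OC)c(OC)c3OC)C2=O)cc1[N+](=O)[O-]`: 790 nM
compound 3 `COc1ccc(/C=C2\Cc3c(cc(OC)c(OC)c3OC)C2=O)cc1Br`: 356 nM

In a functional assay on HeLa cells (Homo sapiens) for antiproliferative activity, read by MTT assay, with a stated time of 48 h (on this read-out lower numbers stand for stronger inhibition of growth and higher numbers for weaker inhibition of growth), compound 2 stands highest of the three numbers: the steps of a 4.6-fold higher number from compound 1 to compound 2 (0.66 log units; beyond the scatter) and a 2.2-fold lower number from compound 2 to compound 3 (0.35 log units; beyond the scatter) both set it above its neighbours, beyond the scatter. Compound 4 `COc1ccc(/C=C2\Cc3c(cc(OC)c(OC)c3OC)C2=O)cc1N` carries the change (amino in place of nitro on an aromatic carbon). The step that bears most on it is a 4.6-fold higher number from compound 1 to compound 2 (0.66 log units; beyond the scatter), where a hydrogen-bond donor gave way to nitro and the number rose; the amino group brings one hydrogen-bond donor back. The step of a 2.2-fold lower number from compound 2 to compound 3 (0.35 log units; beyond the scatter) also shows that leaving nitro lowered the number. A move of a 3.2-fold lower number from compound 2 to compound 4 (0.50 log units; beyond the scatter) is therefore expected, back toward compound 1. Compound 4 is estimated at 250 nM, within 100 nM to 600 nM.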

Compound 4, concentration for 50% growth inhibition: 169 nM
The estimate for compound 4 lay 1.5-fold (0.17 log units) above the measured number; measured number inside the range.
By their numbers in this assay, from the lowest: compounds 4 and 1 (each within the scatter of the next); then compound 3; then compound 2.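

Amino at this position, ortho to a methoxy group, gives a 4.7-fold lower number from compound 2 to compound 4 (0.67 log units; beyond the scatter), which reverses the rise seen on going to nitro. It also gives a 2.1-fold lower number from compound 3 to compound 4 (0.32 log units; beyond the scatter), so amino outperforms bromo here as well. Against hydroxy the exchange gives a 1.0-fold lower number from compound 1 to compound 4 (0.01 log units; within the scatter), so these two hydrogen-bond donor groups cannot be told apart, while nitro and bromo both give higher numbers.

Nothing measured here explains these differences. As far as these compounds go, whether an acetamide or a methylamino group at this position would hold the number of compound 4 remains open.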